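This account rests on a few compounds, and the source may have more. Where it says the series, first, only, none or still open, it means among the compounds named here.

Measured in a functional assay on CHO cells for agonist activity at Free fatty acid receptor 1 (Homo sapiens), read by FLIPR and calcium flux, in the presence of a further agent that is not named here; a lower number here means that less compound is needed, a higher number that more compound is needed for the effect:
compound 1 `O=C(O)CCc1ccc(OCc2ncc(-c3cccc(F)c3)o2)cc1`: 1070 nM
compound 2 `O=C(O)CCc1ccc(OCc2ncc(-c3ccccc3)o2)cc1`: 1600 nM
compound 3 `O=C(O)CCc1ccc(OCc2coc(-c3cccc(F)c3)n2)cc1`: 560 nM

Compound 1 and compound 2 share one core. Compound 3 is built from the same atoms as compound 1, joined differently, and the difference between the two cores is not broken down here. From compound 1 to compound 2 the change is hydrogen in place of fluoro on an aromatic carbon; in this assay this gave a 1.5-fold higher number from compound 1 to compound 2 (0.17 log units; within the scatter), a step that sits within the scatter of repeated measurement. Compound 3 in this assay lies within the scatter of compound 1 and beyond the scatter of compound 2, so the two cores cannot be ranked against each other on this pair alone.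

Compound 4 `O=C(O)CCc1ccc(OCc2coc(-c3ccccc3)n2)cc1` is not yet measured. For the measured compounds named here, it stands to compound 3 as compound 2 stands to compound 1: the change is hydrogen in place of fluoro on an aromatic carbon, the same change at the same place, so the earlier step is the only guide available. Within this series the change occurs twice, once measured and once pending. Applying the measured step to the value of compound 3, 560 nM, gives the expectation that follows. Going by the values given here, for compound 4 the expected step in this assay is a 1.5-fold higher number from compound 3 to compound 4 (0.18 log units; within the scatter), resting on the single earlier instance and therefore held to the same modest size. Compound 4 is thus estimated at 850 nM in this assay, with a likely range from 450 nM to 1700 nM.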

Compound 4, half-maximal effective concentration: 700 nM
Estimate against measurement, compound 4: 1.2-fold (0.08 log units) above; the measured number falls inside the stated range.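

In this assay, hydrogen in place of fluoro on an aromatic carbon gives a 1.3-fold higher number from compound 3 to compound 4 (0.10 log units; within the scatter), so on the second core the step again stays within the scatter. Set side by side, the two steps cannot be told apart: the same change on two cores in this assay, a 1.5-fold higher number (0.17 log units; within the scatter) from compound 1 to compound 2 and a 1.3-fold higher number (0.10 log units; within the scatter) from compound 3 to compound 4, 1.2-fold (0.08 log units) apart, within the scatter of two such steps. This supports treating 3-fluorophenyl to phenyl as a change that carries between these two cores without a step beyond the scatter, but it does not show that the fluoro has a real effect on either core, and two cores cannot speak for any others in the series.

The compounds shown carry only hydrogen or fluoro at this place, so it remains open whether a chloro, methoxy or trifluoromethyl group there would give a step beyond the scatter, and whether such a step would carry from one core to the other. On these data alone, the carboxylic acid and its chain are common to all four compounds, so it also remains open how an amide or a longer chain in their place would behave on either core.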